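Swapping a Double-Bonded Chain for a Triple-Bonded One

A few compounds are considered here, and "the series" means these few. Any claim that something is new, unique, unknown or untested is made for them only; others in the source may bear on it.

In a physicochemical assay for acid dissociation, compound 2 `C=C(C)CCOC[n+]1ccn(C)c1/C=N/O` gives 8.03 and compound 1 `C=CCCOC[n+]1ccn(C)c1/C=N/O` gives 7.97, so the two cannot be told apart. Compound 3 `C#CCC(C)OC[n+]1ccn(C)c1/C=N/O` carries 1-methylbut-3-yn-1-yl in place of 3-methylbut-3-en-1-yl on an oxygen on a saturated carbon. Among the compounds with values here, only one measured step bears on this change, a number 0.06 log units higher from compound 1 to compound 2 (within the scatter), and no measured compound has a triple bond. The expected change is therefore no larger than the scatter, an estimated a number 0.08 log units lower from compound 2 to compound 3 (within the scatter). The estimated value for compound 3 is 7.95, with a range from 7.72 to 8.18.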

Compound 3, acid dissociation constant: 8.03
Compound 3: middle estimate off by 0.08 log units, on the low side; the range from low to high includes it.
By their numbers in this assay, from the lowest: compounds 1, 2 and 3 (each within the scatter of the next).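

Putting 1-methylbut-3-yn-1-yl in place of 3-methylbut-3-en-1-yl in this assay gives no change at the digits printed from compound 2 to compound 3 (within the scatter) here, and putting it in place of but-3-en-1-yl gives a number 0.06 log units higher from compound 1 to compound 3 (within the scatter) here. Within the data shown here, a triple bond, absent from the earlier compounds, can therefore stand in this chain on the oxygen without moving the number beyond the scatter. No measurement accompanying these compounds accounts for this result.

On these data alone, whether a chain ending in an amine or a carboxylic acid would leave this number equally unmoved stays open.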